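This account rests on a few compounds, and the source may have more. Where it says the series, first, only, none or still open, it means among the compounds named here.

Compound 1 `CCN(CC)CN1C(=O)/C(=N/NC(N)=S)c2ccccc21`; compound 2 `CCN(CC)CN1C(=O)/C(=N/NC(=S)Nc2ccc(Cl)cc2)c2cc(Cl)ccc21`; compound 3 `CCN(CC)CN1C(=O)/C(=N/NC(=S)Nc2ccc(Cl)cc2)c2ccccc21`.

In an ADME assay on HeLa cells (Homo sapiens) for cytotoxicity (on this read-out higher numbers stand for lower toxicity in this test and lower numbers for higher toxicity in this test), compound 1 gives only a limit, > 100000 nM. In this assay compound 2 gives 9400 nM and compound 3 gives 9800 nM, so compound 2 holds the lowest of the two numbers, with compound 3 within the scatter of it. The step of an at least 10-fold lower number from compound 1 to compound 3 (1.00 log units; beyond the scatter) was large, whereas a 1.0-fold higher number from compound 2 to compound 3 (0.02 log units; within the scatter) stayed within the scatter. The unmeasured compound 4 `CCN(CC)CN1C(=O)/C(=N/NC(=S)Nc2ccc(OC)cc2)c2cc(Cl)ccc21` differs from compound 2 in that (methoxy in place of chloro on an aromatic carbon). For the measured compounds named here, no measured step touches this part of the molecule; the one swap of a chloro that was measured, a 1.0-fold higher number from compound 2 to compound 3 (0.02 log units; within the scatter), left the number unchanged. Compound 4 is therefore expected to show a 1.1-fold higher number from compound 2 to compound 4 (0.03 log units; within the scatter), nothing beyond the scatter. Compound 4 is estimated at 10000 nM, between 4000 nM and 30000 nM.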

Compound 4, half-maximal cytotoxic concentration: 13200 nM
The estimate for compound 4 lay 1.3-fold (0.12 log units) below the measured number, within the range that was stated.
By their numbers in this assay, from the lowest: compounds 2, 3 and 4 (each within the scatter of the next). At a limit, above all of these: compound 1.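

In this assay, methoxy taking the place of the chloro on the 4-chlorophenyl group gave a 1.4-fold higher number from compound 2 to compound 4 (0.15 log units; within the scatter) and so did not separate 4-methoxyphenyl from 4-chlorophenyl. For the compounds shown here, the earlier compounds had tested only the whole 4-chlorophenyl group and a chloro on the core, so this is the first change on that phenyl ring itself, and it stayed within the scatter. Nothing shown here bears on the reason for this result.

From the compounds shown here alone, whether an amine or a carboxylic acid at this position would also stay within the scatter remains open. So does the effect of a hydrogen there.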